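Isopropyl in Place of Methyl on the Shared Core

This account rests on a few compounds, and the source may have more. Where it says the series, first, only, none or still open, it means among the compounds named here.

Measured compounds:
Compound 1, `COCCNS(=O)(=O)c1ccc(C)c(C#Cc2cc(Cl)ccc2OCC(=O)O)c1`: 88 nM
Compound 2, `Cc1ccc(S(C)(=O)=O)cc1C#Cc1cc(Cl)ccc1OCC(=O)O`: 64 nM

In a functional assay on cells for antagonist activity at prostaglandin D2 receptor 2 (Homo sapiens), read by flow cytometry, with a stated time of 10 min (on this read-out lower numbers stand for stronger inhibition and higher numbers for weaker inhibition), compound 2 gives 64 nM, and compound 1 gives 88 nM. Among the measured compounds shown here, the single step between them, a 1.4-fold lower number from compound 1 to compound 2 (0.14 log units; within the scatter), stays within the scatter, so the two compounds cannot be told apart on these numbers. Compound 3 `CC(C)c1ccc(S(C)(=O)=O)cc1C#Cc1cc(Cl)ccc1OCC(=O)O` keeps the methylsulfonyl group of compound 2 and changes only the small alkyl group on the same ring: isopropyl in place of methyl on an aromatic carbon. For the measured compounds named here, no measured step touches this position; the one step known concerns the group on the sulfonyl sulfur, and it was small. With nothing pointing in either direction, the step of a 1.1-fold higher number from compound 2 to compound 3 (0.04 log units; within the scatter) is expected to stay within the scatter. Compound 3 is therefore estimated at 70 nM, with a range from 25 nM to 200 nM.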

Compound 3, half-maximal inhibitory concentration: 360 nM
Beside the measured number, compound 3's estimate is 5.1-fold (0.71 log units) below it, and the stated range ends below it.
By their numbers in this assay, from the lowest: compounds 2 and 1 (each within the scatter of the next); then compound 3.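

In this assay, among the compounds shown here, the step of a 5.6-fold higher number from compound 2 to compound 3 (0.75 log units; beyond the scatter) goes beyond the scatter, whereas the only earlier step, a 1.4-fold lower number from compound 1 to compound 2 (0.14 log units; within the scatter), stayed within it. This position is therefore the first place in the series where a change clearly moves the number: on this aromatic carbon, ortho to a large group and para to a methylsulfonyl group, isopropyl gives weaker inhibition than methyl, so the two small alkyl groups are not interchangeable here. Nothing available explains why the number rises with this change.

The compounds shown leave open how the number moves with ethyl at this carbon, and whether a different kind of group, such as methoxy or chlorine, matches methyl. Also open, from the compounds shown here alone, is whether isopropyl costs as much when (2-methoxyethyl)amino sits on the sulfonyl sulfur.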